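Cinnamide series at the melanin-concentrating hormone receptor: dichloro variant

The source may hold more compounds than are shown below. What is called first, only, known or untested is meant among the compounds shown, and "the series" means these compounds.

Measured compounds:
compound 1 `CCCc1cc(N)c2cc(NC(=O)/C=C/c3ccc(F)cc3)ccc2n1` — 130 nM
compound 2 `Nc1cc(C2CCCCC2)nc2ccc(NC(=O)/C=C/c3ccc(C(F)(F)F)cc3)cc12` — 1.2 nM

Two compounds have numbers in an assay on isolated protein for displacement of a labelled ligand from melanin-concentrating hormone receptor 1 (Homo sapiens); a higher number here means a weaker inhibitor, a lower number a stronger inhibitor. Compound 1 gives 130 nM, the higher of the two. Compound 2 differs from compound 1 in several places at once. In this assay compound 2 gives 1.2 nM, and the gap between the two numbers lies beyond the usual scatter of this assay. Going by the values given here, no pair that differs in a single place has been measured, so no single change has a known size.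

Compound 3 `CCCc1cc(N)c2cc(NC(=O)/C=C/c3ccc(Cl)c(Cl)c3)ccc2n1` is the next variant of compound 1. The change is 3,4-dichlorophenyl in place of 4-fluorophenyl on a double-bonded chain carbon bound to a double-bonded chain carbon. The shared core, the propyl group and the amine are kept; only the aryl group on the double-bonded chain is exchanged.

Among the compounds with values here, with no measured single-point step to lean on, the expectation for compound 3 rests on compound 1 at 130 nM as the starting point. The step from compound 1 to compound 3 is expected to be a 2.2-fold lower number from compound 1 to compound 3 (0.34 log units; beyond the scatter), a small move toward a lower number that may not clear the scatter. Compound 3 is therefore expected to give about 60 nM in this assay, with a range from 15 nM to 250 nM.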

Compound 3, half-maximal inhibitory concentration: 60 nM
Estimate against measurement, compound 3: no gap at the digits printed; low and high end bracket the measured number.
By their numbers in this assay, from the lowest: compound 2; then compound 3; then compound 1.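

In this assay the series now has its first step at a single place: a 2.2-fold lower number from compound 1 to compound 3 (0.34 log units; beyond the scatter) for 3,4-dichlorophenyl in place of 4-fluorophenyl on a double-bonded chain carbon bound to a double-bonded chain carbon, with the shared core, the propyl group and the amine kept. This shows that the aryl group at this place can be exchanged with a modest gain in the number, a size that compound 1 and compound 2 could not give, as those two differ in several places at once. No measurement at hand speaks to what lies behind the step, which stands as an observed size only.

Compound 2 at 1.2 nM still cannot be divided between its aryl group and the group that stands in place of propyl, and a pair that changes only one of these would be needed to do so. Also open, from the compounds shown here alone, is how a phenyl ring carrying a nitrile or a methoxy group would read at this place on the chain, and how a longer chain in place of propyl would read with the 3,4-dichlorophenyl group kept.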